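The source may hold more compounds than are shown below. What is called first, only, known or untested is meant among the compounds shown, and "the series" means these compounds.

Of the compounds shown here, three that share one core have been measured in an assay on isolated protein for binding affinity to corticotropin-releasing factor receptor 1 (Homo sapiens); on this read-out lower numbers stand for stronger inhibition and higher numbers for weaker inhibition. Compound 1 `CCCCN(CCC)c1cc(C)nc2c(-c3ncc(C(F)(F)F)cc3Cl)c(C)nn12` gives 1.2 nM, compound 2 `CCCN(CC1CC1)c1cc(C)nc2c(-c3ncc(Cl)cc3Cl)c(C)nn12` gives 3.9 nM, and compound 3 `CCCN(CCC)c1cc(C)nc2c(-c3ncc(N(CC)CC)cc3C)c(C)nn12` gives 13 nM. Compound 3 thus stands at the highest number of the three: its nearest neighbour is compound 2, whose value lies beyond the scatter below it, and compound 1 lies further below still.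

Compound 4 `CCCN(CCC)c1cc(C)nc2c(-c3ncccc3C)c(C)nn12` differs from compound 3 in a single place: hydrogen in place of diethylamino on an aromatic carbon. The diethylamino group sits on an aromatic carbon two atoms from the ring nitrogen, meta to a methyl group, and in compound 4 only a hydrogen remains there. Among the compounds with values here, no pair of measured compounds shows this step, so its size cannot be read from the data. Other groups in place of the diethylamino group are carried by compound 1, which gives 1.2 nM, and by compound 2, which gives 3.9 nM; a bare hydrogen is untested. The step from compound 3 to compound 4 is expected to be a 2.3-fold higher number from compound 3 to compound 4 (0.36 log units; beyond the scatter), toward a higher number. Compound 4 is estimated at 30 nM, with a range from 8 nM to 120 nM.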

Compound 4, inhibition constant: 110 nM
Beside the measured number, compound 4's estimate is 3.7-fold (0.56 log units) below it; the measured number falls inside the stated range.
By their numbers in this assay, from the lowest: compound 1; then compound 2; then compound 3; then compound 4.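

Putting a hydrogen in place of the diethylamino group on this aromatic carbon gives, in this assay, an 8.5-fold higher number from compound 3 to compound 4 (0.93 log units; beyond the scatter). Within the data shown here, this is the only comparison here in which just this position changes, so it shows that what sits on this carbon matters: with the rest of the molecule held fixed, the diethylamino group gives the stronger inhibition and the bare hydrogen the weaker. Nothing available explains why the number moves this way.

As far as these compounds go, it remains open whether this gain needs the diethylamino group itself or would also come with a smaller dimethylamino group or a methoxy group on the same carbon. Compound 1 and compound 2 carry other groups at this place but also differ elsewhere, so they cannot settle the question.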